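The source may hold more compounds than are shown below. What is called first, only, known or untested is meant among the compounds shown, and "the series" means these compounds.

Measured compounds:
- Compound 1, `N=C(N)Nc1nc(N)nc2c1ncn2CCO`: > 100000 nM in a functional assay on MCF7 cells (Homo sapiens) for inhibition, read by fluorescence, with a stated time of 72 h; on this read-out lower numbers stand for stronger inhibition and higher numbers for weaker inhibition
- Compound 2, `CC(C)n1cnc2c(NC(=N)N)nc(NCCCO)nc21`: 8800 nM in this assay

Compound 1 sits at the limit of this assay, so its entry is a limit and not a number. Compound 2 gives the only number shown, with 8800 nM in this assay. Within the data shown here, the other entry is the limit of > 100000 nM in this assay, at which 1 of the 2 values shown sits, so compound 2 stands alone as the one compound with a measured half-maximal inhibitory concentration.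

Compound 3, `CC(C)n1cnc2c(NC(=N)N)nc(N3CCC[C@@H]3CO)nc21`, has not yet been measured. It differs from compound 2 in one place: 2-(hydroxymethyl)pyrrolidin-1-yl in place of (3-hydroxypropyl)amino on an aromatic carbon. The (3-hydroxypropyl)amino chain of compound 2 is replaced by a 2-(hydroxymethyl)pyrrolidin-1-yl ring, which carries one defined stereocentre and one fewer hydrogen-bond donor.

Among the measured compounds shown here, no step between measured compounds is available, so the expectation for compound 3 rests on compound 2 alone. A modest gain in inhibition is expected in this assay, somewhat beyond the usual scatter, with the step of a 2.9-fold lower number from compound 2 to compound 3 (0.47 log units; beyond the scatter). Compound 3 is therefore estimated at 3000 nM in this assay, within a range of 700 nM to 15000 nM.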

Compound 3, half-maximal inhibitory concentration: 20400 nM
For compound 3 the middle estimate is 6.8-fold (0.83 log units) below the measured one; measured number outside the range, above it.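

At this position, on an aromatic carbon between two ring nitrogen atoms, the open (3-hydroxypropyl)amino chain can give way to the 2-(hydroxymethyl)pyrrolidin-1-yl ring and inhibition stays measurable, but the exchange brings no gain: in this assay it gives a 2.3-fold higher number from compound 2 to compound 3 (0.37 log units; beyond the scatter). The position therefore accepts a closed ring at a modest cost, and compound 3 remains a real number that can be compared with compound 2. The change alters several things at once, with more heavy atoms, fewer hydrogen-bond donors, a ring in place of a chain and a defined stereocentre, and this single step cannot tell which of them matters.

Compound 1 gives only a limit, which adds no third number for comparison: the limit of > 100000 nM in this assay, at which 1 of the 3 values shown sits. Still open, as far as these compounds go, is how the mirror-image form of the ring, a pyrrolidin-1-yl ring without its hydroxymethyl group, or a longer chain such as (4-hydroxybutyl)amino would behave at this position, and so whether the ring, its stereocentre or its hydroxyl group accounts for the step.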